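Methoxy on the aryl-piperazine: expected effect in the functional assay

The source may hold more compounds than are shown below. What is called first, only, known or untested is meant among the compounds shown, and "the series" means these compounds.

Compound 2 `CCO/N=C(\CCN1CCN(c2ccccc2)CC1)c1ccccc1` is, in a functional assay on HEK293 cells with D(4) dopamine receptor (Homo sapiens) as the target, read by FLIPR (a higher number here means that more compound is needed for the effect, a lower number that less compound is needed), the lower of the two numbers: compound 2 gives 109 nM, while compound 1 `CCCO/N=C(\CCN1CCN(c2ccccn2)CC1)c1ccccc1` gives 320 nM, a gap beyond the usual scatter. Compound 3 `CCO/N=C(\CCN1CCN(c2cccc(OC)c2)CC1)c1ccccc1` has not been measured in this assay . Its change from compound 2 is methoxy in place of hydrogen on an aromatic carbon. Among the compounds with values here, no measured pair shows this exact change, so the step is set as small, leaning toward a lower number but not clearly beyond the scatter. Compound 3 is therefore expected to give 85 nM, within 30 nM to 300 nM. The estimated step is a 1.3-fold lower number from compound 2 to compound 3 (0.11 log units; within the scatter).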

Compound 3, half-maximal effective concentration: 2680 nM
Beside the measured number, compound 3's estimate is 32-fold (1.50 log units) below it; measured number above the stated range.
By their numbers in this assay, from the lowest: compound 2; then compound 1; then compound 3.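

In this assay, within the data shown here, the change from phenyl to 3-methoxyphenyl gives a 25-fold higher number from compound 2 to compound 3 (1.39 log units; beyond the scatter), the first step between compounds that differ in one place. On an aromatic carbon meta to a large group, methoxy therefore carries a large cost, with far more compound needed for the effect. Nothing available accounts for the size of this step. On these data alone, whether the cost belongs to methoxy itself or to any group at this place remains open. A fluorine or a hydroxyl on the same carbon would bear on that, as would methoxy on another aromatic carbon of the ring.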